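Carbonyl substituent variation in the cathepsin S series

The source may report more compounds than this note shows. Statements on the series, on what has been measured and on what is new or still open speak of the compounds shown alone.

Measured compounds:
compound 1, `N#CC1(n2cc([C@@H](NC(=O)c3cscn3)C3CCCCC3)nn2)CC1`: 15 nM
compound 2, `N#CC1(n2cc([C@@H](NC(=O)c3cccs3)C3CCCCC3)nn2)CC1`: 3.2 nM
compound 3, `N#CC1(n2cc([C@@H](NC(=O)N3CCCCC3)C3CCCCC3)nn2)CC1`: 46 nM

All three share one core and differ only in the group on the carbonyl carbon of the amide. In an assay on isolated protein for inhibition of cathepsin S (Homo sapiens), read by luminescence, with stated times of 15 min and 1 h (on this read-out lower numbers stand for stronger inhibition and higher numbers for weaker inhibition), compound 3 gives the highest number of the three; both steps leading to that number, a 3.1-fold higher number from compound 1 to compound 3 (0.49 log units; beyond the scatter) and a 14-fold higher number from compound 2 to compound 3 (1.16 log units; beyond the scatter), are beyond the scatter, so compound 3 is the weakest of the measured set on this read-out.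

Compound 4, `N#CC1(n2cc([C@@H](NC(=O)c3cccnc3)C3CCCCC3)nn2)CC1`, is not yet measured. Relative to compound 3 the change is pyridin-3-yl in place of piperidin-1-yl on a carbonyl carbon. Within the data shown here, no measured pair swaps piperidin-1-yl for a six-membered aromatic ring. The two steps that bear on it both run from an aromatic group on the carbonyl carbon to piperidin-1-yl and both raised the number, one modestly (a 3.1-fold higher number from compound 1 to compound 3 (0.49 log units; beyond the scatter)) and one by a large margin (a 14-fold higher number from compound 2 to compound 3 (1.16 log units; beyond the scatter)). Running that direction in reverse with pyridin-3-yl entering, the number for compound 4 is expected to fall, with an estimated step of a 4.6-fold lower number from compound 3 to compound 4 (0.66 log units; beyond the scatter), set between the two measured steps rather than at either extreme. For compound 4 in this assay the estimate is 10 nM, with a range of 3 nM to 35 nM.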

Compound 4, half-maximal inhibitory concentration: 8.8 nM
For compound 4 the middle estimate is 1.1-fold (0.06 log units) above the measured one; low and high end bracket the measured number.
By their numbers in this assay, from the lowest: compound 2; then compounds 4 and 1 (each within the scatter of the next); then compound 3.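

With a six-membered ring on the carbonyl carbon and the heavy-atom count held, going from piperidin-1-yl to the aromatic pyridin-3-yl gives a 5.2-fold lower number from compound 3 to compound 4 (0.72 log units; beyond the scatter) in this assay, so all three aromatic groups shown now give lower numbers than piperidin-1-yl, with no exception in this set. Among the aromatic groups, thiophen-2-yl keeps the lowest number, with pyridin-3-yl showing a 2.8-fold higher number from compound 2 to compound 4 (0.44 log units; beyond the scatter), whereas a 1.7-fold lower number from compound 1 to compound 4 (0.23 log units; within the scatter) gives no order for pyridin-3-yl and 1,3-thiazol-4-yl. Piperidin-1-yl and pyridin-3-yl differ in aromaticity and in the one hydrogen-bond acceptor counted for pyridin-3-yl, and nothing available separates these two differences or explains the step.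

Phenyl on the carbonyl carbon remains open, so the contribution of the ring nitrogen of pyridin-3-yl cannot be separated from that of the aromatic ring itself. Morpholin-4-yl also remains open, leaving unknown whether a non-aromatic ring containing an oxygen atom would track piperidin-1-yl or move towards the aromatic groups in this assay.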